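This account rests on a few compounds, and the source may have more. Where it says the series, first, only, none or still open, it means among the compounds named here.

Compound 1 `CCCN(CC[C@H]1CC[C@H](NC(=O)c2cccc(-n3cncn3)c2)CC1)[C@H]1CCc2nc(N)sc2C1`: 3 nM in an assay on brain for displacement of a labelled ligand from D(3) dopamine receptor (Rattus norvegicus); a lower number here means a stronger inhibitor, a higher number a weaker inhibitor
Compound 2 `CCCN(CC[C@H]1CC[C@H](NC(=O)c2cccc(-n3ccnc3)c2)CC1)[C@H]1CCc2nc(N)sc2C1`: 1.1 nM
Compound 3 `CCCN(CC[C@H]1CC[C@H](NC(=O)c2ccc(-n3cncn3)cc2)CC1)[C@H]1CCc2nc(N)sc2C1`: 2.4 nM

Compound 2 holds the lowest number of the three, with a gap of a 2.7-fold lower number from compound 1 to compound 2 (0.44 log units; beyond the scatter) and of a 2.2-fold higher number from compound 2 to compound 3 (0.34 log units; beyond the scatter), both beyond the scatter. Compound 4 `CCCN(CC[C@H]1CC[C@H](NC(=O)c2cccc(-c3noc(CC)n3)c2)CC1)[C@H]1CCc2nc(N)sc2C1` differs from compound 2 in one place: 5-ethyl-1,2,4-oxadiazol-3-yl in place of 1H-imidazol-1-yl on an aromatic carbon. The step that bears on this is a 2.7-fold lower number from compound 1 to compound 2 (0.44 log units; beyond the scatter), where one five-membered aromatic ring replaced another at the same position and gave a modest shift. The other step, a 1.3-fold lower number from compound 1 to compound 3 (0.10 log units; within the scatter), stayed within the scatter. Another ring swap is therefore expected to move this assay only modestly, most likely back toward a higher number, as a 2.7-fold higher number from compound 2 to compound 4 (0.44 log units; beyond the scatter). Compound 4 is estimated at 3 nM, within a range of 1 nM to 10 nM.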

Compound 4, inhibition constant: 1.5 nM
Compound 4: middle estimate off by 2.0-fold (0.30 log units), on the high side, within the range that was stated.
By their numbers in this assay, from the lowest: compounds 2, 4, 3 and 1 (each within the scatter of the next, the first and the last beyond it).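

In this assay, this position on the aromatic carbon accepts 5-ethyl-1,2,4-oxadiazol-3-yl, with 7 heavy atoms against 5 for 1H-imidazol-1-yl: the change gives a 1.4-fold higher number from compound 2 to compound 4 (0.13 log units; within the scatter), and the comparison with the triazole gives a 2.0-fold lower number from compound 1 to compound 4 (0.30 log units; within the scatter), both within the scatter. So a ring joined through carbon and carrying an ethyl chain fits here as well as the smaller rings joined through nitrogen. No measurement here explains this tolerance. Still open, on these data alone, is whether a longer chain than ethyl on the oxadiazole, or an amine in place of the ring, would hold the number in this assay.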